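The source may hold more compounds than are shown below. What is called first, only, known or untested is meant among the compounds shown, and "the series" means these compounds.

Compound 1 `CCOC(=O)C1=C(NN=C(C(C)=O)C(C)=O)Nc2[nH]nc(C)c2C1c1ccc(N(C)C)cc1` is the reference point here. In a functional assay on HepG2 cells (Homo sapiens) for inhibition, read by MTT assay, with a stated time of 48 h (on this read-out higher numbers stand for weaker inhibition and lower numbers for stronger inhibition), compound 1 gives 8480 nM, the lowest of the three numbers at hand. Two close relatives change only the group attached to the amine nitrogen. Compound 2 `CCOC(=O)C1=C(N/N=C(\C#N)C(N)=O)Nc2[nH]nc(C)c2C1c1ccc(N(C)C)cc1` gives 48400 nM, and compound 3 `CCOC(=O)C1=C(NN=C(C#N)C#N)Nc2[nH]nc(C)c2C1c1ccc(N(C)C)cc1` gives 13700 nM. The step of a 5.7-fold higher number from compound 1 to compound 2 (0.76 log units; beyond the scatter) lies beyond the scatter, whereas a 1.6-fold higher number from compound 1 to compound 3 (0.21 log units; within the scatter) lies within it; between those two relatives the step of a 3.5-fold lower number from compound 2 to compound 3 (0.55 log units; beyond the scatter) is again modest. Compound 4 `CCOC(=O)C1=C(N/N=C(/Br)c2ccccc2)Nc2[nH]nc(C)c2C1c1ccc(N(C)C)cc1` has not yet been measured. It differs from compound 1 in a group of 9 heavy atoms (7 carbon, 1 nitrogen, 1 bromine; one six-membered aromatic ring of carbon only) in place of a group of 8 heavy atoms (5 carbon, 1 nitrogen, 2 oxygen; no ring), on an amine nitrogen. All three measured steps concern this same position, and together they show that exchanging the group on the amine nitrogen shifts the number only modestly, in either direction. A shift of similar or smaller size is therefore expected here, and the step expected from this change is a 1.4-fold lower number from compound 1 to compound 4 (0.15 log units; within the scatter). For compound 4 the estimated value is 6000 nM, with a range from 2000 nM to 20000 nM.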

Compound 4, half-maximal inhibitory concentration: 72000 nM
The estimate for compound 4 lay 12-fold (1.08 log units) below the measured number, and the stated range ends below it.
By their numbers in this assay, from the lowest: compounds 1 and 3 (each within the scatter of the next); then compounds 2 and 4 (each within the scatter of the next).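

Within the data shown here, with the ring and bromine on the amine nitrogen, the number moves well away from the two lowest compounds, with an 8.5-fold higher number from compound 1 to compound 4 (0.93 log units; beyond the scatter) and a 5.3-fold higher number from compound 3 to compound 4 (0.72 log units; beyond the scatter), so compound 2 is no longer the only compound set apart from that pair. The step of a 1.5-fold higher number from compound 2 to compound 4 (0.17 log units; within the scatter) places the two higher compounds together, even though their groups differ in the counts of atoms and in the presence of a ring. Nothing available explains why these groups give these numbers.

The entering group brings the aromatic ring and the bromine together, so the compounds shown do not tell which of the two goes with the higher number. A group with a methyl in place of the bromine, or one with a plain chain in place of the ring, would separate those two parts.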